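A few compounds are considered here, and "the series" means these few. Any claim that something is new, unique, unknown or untested is made for them only; others in the source may bear on it.

Working notes on the series, cytotoxicity readout. Two compounds built on the shared core have numbers in an ADME assay on MDCK cells (Canis lupus familiaris) for cytotoxicity; a lower number here means that less compound is tolerated, a higher number that more compound is tolerated. Compound 1 `CCN(CC)CN1C(=O)/C(=N/NC(=S)Nc2ccc(Cl)cc2)c2ccccc21` gives 800 nM in this assay. Compound 2 `CCN(CC)CN1C(=O)/C(=N/NC(=S)Nc2ccc(OC)cc2)c2ccccc21` gives 4000 nM in this assay. Among the compounds with values here, the only step between them, a 5.0-fold higher number from compound 1 to compound 2 (0.70 log units; beyond the scatter), shows that exchanging the substituent on the aromatic carbon alone moves the number beyond the scatter. Within the data shown here, compound 1 therefore holds the lower of the two numbers, the only other number being that of compound 2.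

Compound 3 `CCN(CC)CN1C(=O)/C(=N/NC(N)=S)c2ccccc21` differs from compound 1 as follows: hydrogen in place of 4-chlorophenyl on an amide-type nitrogen. Among the measured compounds shown here, the one measured step, a 5.0-fold higher number from compound 1 to compound 2 (0.70 log units; beyond the scatter), bears on this only loosely: it changes a substituent on the ring while keeping the 4-chlorophenyl in place, whereas here the 4-chlorophenyl leaves altogether and the difference, cut one bond further out, reads (4-chlorophenyl)amino to amino. For the measured compounds named here, no measured step removes the ring. Because a substituent exchange already gave a 5.0-fold higher number from compound 1 to compound 2 (0.70 log units; beyond the scatter), a step of at least that order is expected for the larger change, with the direction uncertain and a higher number somewhat favoured; the expected step is a 3.1-fold higher number from compound 1 to compound 3 (0.49 log units; beyond the scatter). For compound 3 the estimated value in this assay is 2500 nM, with a range from 600 nM to 10000 nM.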

Compound 3, minimum cytotoxic concentration: 100000 nM
Compound 3: middle estimate off by 40-fold (1.60 log units), on the low side; measured number outside the range, above it.
By their numbers in this assay, from the lowest: compound 1; then compound 2; then compound 3.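

In this assay the aryl group on the amide-type nitrogen matters far more than the substituent it carries: hydrogen in place of 4-chlorophenyl gives a 130-fold higher number from compound 1 to compound 3 (2.10 log units; beyond the scatter) and hydrogen in place of 4-methoxyphenyl gives a 25-fold higher number from compound 2 to compound 3 (1.40 log units; beyond the scatter) while the exchange on the ring gives only a 5.0-fold higher number from compound 1 to compound 2 (0.70 log units; beyond the scatter) in comparison. Removing the aryl group raises the number from either starting point, so the direction of the change does not depend on which of these two substituents the ring carries, and compound 3 holds the highest number of the three, with its steps to both others beyond the scatter. Nothing measured here accounts for the size of these steps.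

The compounds shown leave open whether any group on this nitrogen lowers the number or whether an aromatic ring is needed, a question that a methyl or a cyclohexyl group in the same place would address. They also leave open how an unsubstituted phenyl group would compare with 4-chlorophenyl and 4-methoxyphenyl, and whether a ring carrying a hydroxyl or a dimethylamino group would stay close to those two.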